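A few compounds are considered here, and "the series" means these few. Any claim that something is new, unique, unknown or untested is made for them only; others in the source may bear on it.

Working notes on the series, followed in a functional assay on NCI-H322M cells (Homo sapiens) for inhibition, with a stated time of 48 h; on this read-out higher numbers stand for weaker inhibition of growth and lower numbers for stronger inhibition of growth. Compound 3 (`C=CCc1c(O)c(C(=O)/C=C/c2ccccc2)c(OC)c2ccoc12`) gives 3190 nM. Compound 2 (`COc1c(C(=O)/C=C/c2ccc(Cl)cc2)c(O)c(Br)c2occc12`) gives 5220 nM, and the two values lie within the scatter of each other, so they do not separate. Compound 1 (`COc1ccccc1/C=C/C(=O)c1c(O)cc2occc2c1OC`) is reported only as a limit of > 100000 nM, not as a number. Compound 3 therefore sits level with compound 2 among the two numerical values in this assay.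

The next compound is compound 4 (`C=CCc1c(O)c(C(=O)/C=C/c2ccc(Cl)cc2)c(OC)c2ccoc12`), which replaces hydrogen with chloro on an aromatic carbon of the six-membered aromatic ring of carbon only, para to a large group: chloro in place of hydrogen on an aromatic carbon. The same difference reads phenyl to 4-chlorophenyl.

Among the measured compounds shown here, no pair of measured compounds differs in one place only, so the series offers no direct measure of this change. For the measured compounds named here, the only guide is compound 2, which already carries a 4-chlorophenyl and gives 5220 nM, though it differs from compound 3 elsewhere as well. A change beyond the scatter is not expected in either direction. The expected step, a 1.0-fold higher number from compound 3 to compound 4 (0.00 log units; within the scatter), is an estimate and remains small. For compound 4 the estimated value is 3200 nM, with an expected range of 1100 nM to 9500 nM.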

Compound 4, concentration for 50% growth inhibition: 4880 nM
Beside the measured number, compound 4's estimate is 1.5-fold (0.18 log units) below it; the range from low to high includes it.
By their numbers in this assay, from the lowest: compounds 3, 4 and 2 (each within the scatter of the next). At a limit, above all of these: compound 1.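

Among the compounds shown here, the pair gives a first direct reading in this assay of chloro in place of hydrogen on an aromatic carbon, para to a large group: a 1.5-fold higher number from compound 3 to compound 4 (0.18 log units; within the scatter), so phenyl and 4-chlorophenyl do not separate on this allyl-bearing scaffold. A second single change, allyl in place of bromo on an aromatic carbon, reads a 1.1-fold lower number from compound 2 to compound 4 (0.03 log units; within the scatter), so this exchange does not separate its two compounds either, and neither of the two changes shown moves the number beyond the scatter. Nothing measured here bears on the reason for this result.

The compounds shown compare only hydrogen and chloro at this position of the phenyl ring, so the effect of a methoxy group, an amine or a carboxylic acid there remains open. Also open, on these data alone, is whether a longer chain in place of allyl, or a hydroxyl or an amine on that same aromatic carbon of the core, would give a number that separates from those of compound 3 and compound 4.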